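The compounds below may be only part of what the source reports. "The series", "measured", "known", "first", "only" and "open" are said of these compounds alone.

Compound 1 `CCC(C)OC(=O)/C=C/c1ccccc1`: 18%
Compound 2 `CC(C)OC(=O)/C=C/c1ccc(C(C)C)cc1`: 18%

In a functional assay on the whole organism for inhibition, with Brassica rapa subsp. chinensis as the target, with a stated time of 3 days, tested at 100 ppm (on this read-out higher numbers stand for more inhibition of growth at the one concentration tested and lower numbers for less inhibition of growth), compound 1 gives 18%, and compound 2 stands level with it at 18%, within the usual scatter. Both values come from a single concentration, and neither compound separates from the other. Compound 3 `CC(C)CNC(=O)/C=C/c1ccccc1` has not yet been measured. It has isobutylamino in place of sec-butoxy on a carbonyl carbon. Among the compounds with values here, no measured pair of compounds shows this exchange, so the data offer no direct guide to its size. A small upward step in this assay is expected, and it may well not rise beyond the scatter. The estimated change is a number 6 percentage points higher from compound 1 to compound 3 (within the scatter). For compound 3 the expected value is 24%, with an estimated range from 8% to 45%.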

Compound 3, percent growth inhibition at one concentration: 34%
Compound 3: middle estimate off by 10 percentage points, on the low side; the measured number falls inside the stated range.
By their numbers in this assay, from the lowest: compounds 1 and 2 (each within the scatter of the next); then compound 3.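

In this assay, isobutylamino in place of sec-butoxy on a carbonyl carbon gives a number 16 percentage points higher from compound 1 to compound 3 (beyond the scatter), so this position can move the read-out past the scatter, which compounds 1 and 2 did not show. The exchange keeps the count of 5 heavy atoms and leaves both groups without a ring or net charge, but it puts nitrogen for oxygen and brings 1 hydrogen-bond donor where sec-butoxy has none. This single step rests on one concentration, and nothing at hand bears on why the number rises.

The compounds shown leave open whether the rise belongs to the nitrogen or to the change in branching, which a sec-butylamino or an isobutoxy group on the same carbonyl carbon could separate. They also leave open whether a longer chain on the nitrogen would carry the number further.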